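The source may report more compounds than this note shows. Statements on the series, on what has been measured and on what is new or still open speak of the compounds shown alone.

Working notes on the series. Of the compounds shown here, three of the shared core have been measured in an assay on HEK293 cells for positive allosteric modulation of metabotropic glutamate receptor 2 (Rattus norvegicus), read by thallium flux, with a stated time of 2.5 min; a higher number here means a larger maximal response, a lower number a smaller maximal response. Compound 1 `Cc1c(OCCCCOc2ccc(C(=O)O)cc2Cl)ccc(C(=O)CC2CCCC2)c1O` gives 82.2%, the lowest of the three numbers. Compound 2 `Cc1c(OCCCCOc2ccc(C(=O)O)cc2F)ccc(C(=O)CC(C)C)c1O` gives 85%, which lies within the scatter of the number for compound 1. Compound 3 `Cc1cc(OCCCCOc2ccc(C(=O)CC(C)C)c(O)c2C)ccc1C(=O)O` gives 93.3%, which lies beyond the scatter from compound 1. Within the data shown here, the only measured step that exchanges the aryl group on the oxygen on the saturated carbon, a number 8.3 percentage points higher from compound 2 to compound 3 (within the scatter), stays within the scatter.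

Compound 4 `Cc1c(OCCCCOc2cccc(C(=O)O)c2)ccc(C(=O)CC2CCCC2)c1O` has not yet been measured in this assay. Against compound 1 it differs in one place:

3-carboxyphenyl in place of 4-carboxy-2-chlorophenyl on an oxygen on a saturated carbon

Among the measured compounds shown here, this is a change of the same kind as the one measured step of this sort, which remained within the scatter. No step beyond the scatter is therefore expected in this assay for compound 4. The step expected from compound 1 is a number 2.8 percentage points higher from compound 1 to compound 4 (within the scatter). Compound 4 is estimated at 85%, with an expected range from 72% to 98%.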

Compound 4, largest response reached (reported as percent of maximum), in percent of the reference or control that the assay uses: 80.6%
For compound 4 the middle estimate is 4.4 percentage points above the measured one; low and high end bracket the measured number.
By their numbers in this assay, from the lowest: compounds 4, 1, 2 and 3 (each within the scatter of the next, the first and the last beyond it).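

The exchange of 4-carboxy-2-chlorophenyl for 3-carboxyphenyl, which removes the chlorine and changes the carboxyphenyl pattern in one step, gives a number 1.6 percentage points lower from compound 1 to compound 4 (within the scatter) in this assay and extends the earlier finding to the core of compound 1. With a number 8.3 percentage points higher from compound 2 to compound 3 (within the scatter) as the other such exchange, neither measured change of the aryl group on this oxygen on a saturated carbon leaves the scatter, and no compound shown goes against this. Nothing available explains why the response holds across these exchanges.

On these data alone, whether the carboxylic acid itself can be replaced at this place, for example by a primary amide or a tetrazole, remains open. Also open, as far as these compounds go, is whether any aryl exchange here can produce a step beyond the scatter.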